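Isopropoxy versus trifluoromethyl-ethoxy on two biaryl oxadiazole cores

A few compounds are considered here, and "the series" means these few. Any claim that something is new, unique, unknown or untested is made for them only; others in the source may bear on it.

Compound 1 `Cc1cc(CCC(=O)O)ccc1-c1noc(-c2ccc(OC(C)C)c(C#N)c2)n1` and compound 2 `Cc1cc(CCC(=O)O)ccc1-c1noc(-c2ccc(OC(C)C(F)(F)F)c(C#N)c2)n1` share a core and differ by trifluoromethyl in place of methyl on a saturated chain carbon bound to an oxygen on an aromatic ring and a saturated chain carbon. In a functional assay on CHO cells with sphingosine 1-phosphate receptor 2 (Homo sapiens) as the target, read by GTPgammaS binding (a higher number here means that more compound is needed for the effect, a lower number that less compound is needed), compound 1 reaches only the limit > 10000 nM. Compound 2 likewise gives only the limit > 10000 nM. The step that the two limits leave unreadable from compound 1 to compound 2 therefore cannot be sized.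

Compound 3 `Cc1cc(CCC(=O)O)ccc1-c1noc(-c2cnc(OC(C)C)c(Cl)c2)n1` carries a different core; the difference between the two cores is not broken down here. In this assay compound 3 also stops at the limit > 10000 nM, so all three values sit at the limit of > 10000 nM in this assay, at which 3 of the 3 values shown sit.

Compound 4 `Cc1cc(CCC(=O)O)ccc1-c1noc(-c2cnc(OC(C)C(F)(F)F)c(Cl)c2)n1`, not yet measured, differs from compound 3 by trifluoromethyl in place of methyl on a saturated chain carbon bound to an oxygen on an aromatic ring and a saturated chain carbon, the same change as from compound 1 to compound 2. Since that change left both measured compounds at the limit, compound 4 is expected to remain there as well, with an expected step that the limit leaves unreadable from compound 3 to compound 4. The estimate for compound 4 is 15000 nM, from 5000 nM to 50000 nM.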

Compound 4, half-maximal effective concentration: > 10000 nM
Compound 4: no number, only a limit (the forecaster's own chance of this, stated with the estimate: 85%); the middle value does not contradict the limit.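

In this assay, among the compounds shown here, both compound 3 and compound 4 stop at a limit, so no step between them can be read: the limit of > 10000 nM in this assay, at which 4 of the 4 values shown sit.

The compounds shown leave open how isopropoxy and 1-(trifluoromethyl)ethoxy compare where a compound gives a number rather than a limit.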